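A Fluoropyridine Replaces a Benzimidazole

The source may hold more compounds than are shown below. What is called first, only, known or untested is meant among the compounds shown, and "the series" means these compounds.

Compound 1 `N#Cc1ccc(N2CCc3cc(-c4cncnc4)ccc32)cc1C(F)(F)F` gives "not determined" (no result reported)
Compound 2 `CCN(c1ccc(C#N)c(Cl)c1)c1cc(-n2cnc3ccccc32)ccc1C` gives 3040 nM

Among the measured compounds shown here, in a functional assay on CWR22R cells (Homo sapiens) for antiproliferative activity, read by CCK-8 assay, with a stated time of 6 days (a lower number here means a stronger inhibitor, a higher number a weaker inhibitor), compound 2 gives 3040 nM and this is the only number so far, as compound 1 has no result. So compound 2 cannot yet be ranked as strong or weak against a neighbour.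

The next molecule is compound 3 `CCN(c1ccc(C#N)c(Cl)c1)c1cc(-c2ccc(F)nc2)ccc1C`, which has not yet been measured. It carries 6-fluoropyridin-3-yl in place of 1H-benzimidazol-1-yl on an aromatic carbon, and the count of what changes is 6-fluoropyridin-3-yl in place of 1H-benzimidazol-1-yl on an aromatic carbon here.

For the measured compounds named here, no measured pair shows what a swap like this does, so any forecast is uncertain. A small move toward stronger inhibition is expected, no larger than the usual scatter between repeats. The estimated change is a 1.7-fold lower number from compound 2 to compound 3 (0.23 log units; within the scatter) in this assay and could still go either way. Compound 3 has an estimated value of 1800 nM (expected range 400 nM to 7000 nM).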

Compound 3, half-maximal inhibitory concentration: 16500 nM
Compound 3: the middle estimate sits 9.2-fold (0.96 log units) below what was measured; the measured number lies above the stated range.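

In this assay, putting 6-fluoropyridin-3-yl in place of 1H-benzimidazol-1-yl gives a 5.4-fold higher number from compound 2 to compound 3 (0.73 log units; beyond the scatter), so this aromatic carbon, para to a methyl group, is sensitive to the group it carries. Of the two groups, 1H-benzimidazol-1-yl gives the stronger inhibitor, which means a single-ring replacement with fewer heavy atoms does not keep the activity of compound 2 here. The swap alters ring count, ring atoms and the fluorine all at once, and nothing measured shows which of these differences accounts for the step.

The compounds shown leave open whether an unsubstituted pyridin-3-yl or a plain phenyl ring at this carbon would fall nearer compound 2 or compound 3. They also leave open how a small amine or a carboxylic acid would fare at the same place.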